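A few compounds are considered here, and "the series" means these few. Any claim that something is new, unique, unknown or untested is made for them only; others in the source may bear on it.

Compound 3, `COc1ccc2sc(NC(=O)c3ccc(C)cc3)nc2c1`, is one of three compounds tested in a functional assay on SK-HEP1 cells (Homo sapiens) for antiproliferative activity, read by sulforhodamine B assay; a lower number here means a stronger inhibitor of growth, a higher number a weaker inhibitor of growth. In this assay compound 3 gives only the limit > 10 ug/mL, which is a limit of the assay and not a number. Compound 1, `COc1ccc2sc(NC(=O)c3ccc(C(F)(F)F)cc3)nc2c1`, likewise gives only the limit > 10 ug/mL in this assay. Compound 2, `Cc1cc2nc(NC(=O)Nc3ccccc3C)sc2cc1C`, is built differently around the shared core and gives 0.18 ug/mL in this assay. Among the measured compounds shown here, the single measured step, a step that the two limits leave unreadable from compound 1 to compound 3, cannot be read in size, since both of its ends sit at the limit of > 10 ug/mL in this assay, at which 2 of the 3 values shown sit.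

Compound 4, `COc1ccc2sc(NC(=O)c3ccc([N+](=O)[O-])cc3)nc2c1`, differs from compound 3 in one place: nitro in place of methyl on an aromatic carbon. For the measured compounds named here, no measured step involves a nitro group, and the only step that touches this same position, a step that the two limits leave unreadable from compound 1 to compound 3, has no readable size. The data give no sign that a change at this position moves a compound away from the limit, so compound 4 is expected to stay at or near the limit, with a number no higher from compound 3 to compound 4 (the limit leaves the size open) expected as the step. Compound 4 is therefore estimated at 10 ug/mL, within a range from 3 ug/mL to 30 ug/mL, and is most likely to be reported again only as a limit.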

Compound 4, concentration for 50% growth inhibition: > 10 ug/mL
Compound 4: only a limit was reported; the forecaster's own chance of this, stated with the estimate: 70%; the middle value lies on the limit itself.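

Compound 4, like compound 1 and compound 3, is reported only as a limit of the assay and not as a number, and the steps among these three cannot be read in size: the limit of > 10 ug/mL in this assay, at which 3 of the 4 values shown sit. The compounds shown leave open whether trifluoromethyl, methyl and nitro at this place differ at all in this assay and, if they do, by how much.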